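This account rests on a few compounds, and the source may have more. Where it says the series, first, only, none or still open, it means among the compounds named here.

Of the compounds shown here, three that share one core have been measured in an assay on CHO cells for displacement of a labelled ligand from adenosine receptor A2b (Homo sapiens), read by scintillation counting, with a stated time of 75 min, in the presence of a further agent that is not named here; on this read-out higher numbers stand for weaker inhibition and lower numbers for stronger inhibition. Compound 1 `CCCn1c(=O)[nH]c2nc(-c3ccc(S(=O)(=O)N4CCN(c5ccc(Cl)cc5F)CC4)cc3)[nH]c2c1=O` carries a 4-chloro-2-fluorophenyl group on an amine nitrogen in a ring, and in this assay compound 1 gives 1.91 nM. Compound 2 `CCCn1c(=O)[nH]c2nc(-c3ccc(S(=O)(=O)N4CCN(Cc5cccc(C)c5)CC4)cc3)[nH]c2c1=O` carries a 3-methylbenzyl group at that place, and compound 2 gives 0.397 nM. Compound 3 `CCCn1c(=O)[nH]c2nc(-c3ccc(S(=O)(=O)N4CCN(c5ccccc5C)CC4)cc3)[nH]c2c1=O` carries a 2-methylphenyl group there, and compound 3 gives 0.432 nM. Compound 3 thus stands second of the three numbers: the step of a 1.1-fold higher number from compound 2 to compound 3 (0.04 log units; within the scatter) lies within the scatter, while the step of a 4.4-fold lower number from compound 1 to compound 3 (0.65 log units; beyond the scatter) lies beyond it.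

Compound 4 `CCCn1c(=O)[nH]c2nc(-c3ccc(S(=O)(=O)N4CCN(c5cccc(Cl)c5)CC4)cc3)[nH]c2c1=O` has not yet been measured. It differs from compound 3 in one place: 3-chlorophenyl in place of 2-methylphenyl on an amine nitrogen in a ring. Among the compounds with values here, two measured steps bear on this kind of swap of the group on that nitrogen, a 4.4-fold lower number from compound 1 to compound 3 (0.65 log units; beyond the scatter) and a 4.8-fold lower number from compound 1 to compound 2 (0.68 log units; beyond the scatter), both modest, while a 1.1-fold higher number from compound 2 to compound 3 (0.04 log units; within the scatter) shows that two different groups can also give numbers within the scatter. Within the data shown here, the only measured group that carries a chlorine, in compound 1 with 1.91 nM, gave the highest number, so a small rise is expected for compound 4, though one that may stay within the scatter. For compound 4 the expected step is a 1.6-fold higher number from compound 3 to compound 4 (0.21 log units; within the scatter). Compound 4 is therefore estimated to give 0.7 nM, within a range from 0.25 nM to 2 nM.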

Compound 4, inhibition constant: 0.342 nM
Estimate against measurement, compound 4: 2.0-fold (0.31 log units) above; the range from low to high includes it.
By their numbers in this assay, from the lowest: compounds 4, 2 and 3 (each within the scatter of the next); then compound 1.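

Replacing 2-methylphenyl with 3-chlorophenyl leaves the number essentially unchanged, with a 1.3-fold lower number from compound 3 to compound 4 (0.10 log units; within the scatter) inside the usual scatter, and the comparison with the benzyl compound, a 1.2-fold lower number from compound 2 to compound 4 (0.06 log units; within the scatter), also stays within it, so three different groups on this amine nitrogen now give numbers that cannot be told apart. A chlorine on the aromatic ring therefore does not by itself go with a higher number: compound 4 carries one too, yet the step is a 5.6-fold lower number from compound 1 to compound 4 (0.75 log units; beyond the scatter), and among these four compounds only compound 1, with its 4-chloro-2-fluorophenyl group, stands apart beyond the scatter. Nothing in the data shown explains why compound 1 differs from the other three.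

These compounds cannot separate the part played by the fluorine from the part played by where the chlorine sits, a question that a plain 4-chlorophenyl or 2-fluorophenyl group on the same nitrogen would help to settle. From the compounds shown here alone, it also remains open whether this position would tolerate a group of another kind, such as a carboxylic acid or an amine on the aromatic ring, as it tolerates the methyl and chlorine groups seen here.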